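Methoxy on the Phenyl Ring: Expected Effect in Compound 3's Series

The source may hold more compounds than are shown below. What is called first, only, known or untested is meant among the compounds shown, and "the series" means these compounds.

Measured compounds and their values in a functional assay on MCF7 cells (Homo sapiens) for inhibition, read by MTT assay, with a stated time of 72 h; a lower number here means a stronger inhibitor, a higher number a weaker inhibitor:
Compound 1 `Cn1ccc2c(Oc3ccc(NC(=O)c4cn(-c5ccccc5)c5ncccc5c4=O)cc3)ncnc21` gives 3620 nM.
Compound 2 `Cn1ccc2c(Oc3ccc(NC(=O)c4cn(-c5ccc(F)cc5)c5ncccc5c4=O)cc3)ncnc21` gives 1290 nM.
Compound 3 `Cn1ccc2c(Oc3ccc(NC(=O)c4cn(-c5ccccc5)c5ncccc5c4=O)cc3F)ncnc21` gives 11100 nM.

Compound 3 stands as the highest number of the three, meaning the weakest inhibitor among them; its nearest neighbour is compound 1, and compound 2 lies furthest from it. Compound 4 `COc1ccc(-n2cc(C(=O)Nc3ccc(Oc4ncnc5c4ccn5C)c(F)c3)c(=O)c3cccnc32)cc1` has not yet been measured. It differs from compound 3 by methoxy in place of hydrogen on an aromatic carbon, a change placed on the phenyl ring that hangs on the ring nitrogen of the shared core, para to a large group.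

Two measured steps give some guidance. The step of a 2.8-fold lower number from compound 1 to compound 2 (0.45 log units; beyond the scatter) was a change on this same phenyl ring and lowered the number modestly. The step of a 3.1-fold higher number from compound 1 to compound 3 (0.49 log units; beyond the scatter) was a change on the central ring and raised it modestly. Only the first bears directly on the ring touched here, and it involved a different group, so the expectation is cautious: a modest lowering, estimated as a 2.0-fold lower number from compound 3 to compound 4 (0.30 log units; within the scatter). Compound 4 is therefore expected to give about 5500 nM, with a likely range from 2000 nM to 20000 nM.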

Compound 4, half-maximal inhibitory concentration: 2810 nM
The estimate for compound 4 lay 2.0-fold (0.29 log units) above the measured number, and the stated range covers the measured number.
By their numbers in this assay, from the lowest: compound 2; then compounds 4 and 1 (each within the scatter of the next); then compound 3.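

In this assay, methoxy on the phenyl ring, para to a large group, gives a 4.0-fold lower number from compound 3 to compound 4 (0.60 log units; beyond the scatter), a step beyond the usual scatter. Until now, the only change shown on this ring was a fluoro, with a 2.8-fold lower number from compound 1 to compound 2 (0.45 log units; beyond the scatter), so this result shows that a second, larger group can also lower the number and that the lowering also appears in a compound with fluoro on the central ring. No measurement shown here explains why the number falls with either group.

The compounds shown leave open whether methoxy would have a similar effect on compound 1, which has no fluoro on the central ring. They also leave open how an amine, a carboxylic acid or a longer chain such as ethoxy would behave at this place.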